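Bromo for Fluoro on the Fused Ring of Compound 3

A few compounds are considered here, and "the series" means these few. Any claim that something is new, unique, unknown or untested is made for them only; others in the source may bear on it.

Among the compounds with values here, compound 3 `Fc1ccc(-c2nn(-c3ccccc3)cc2-c2nc3cc(F)ccc3[nH]2)cc1` gives 1130 nM in a functional assay on A549 cells (Homo sapiens) for antiproliferative activity, read by MTT assay, with a stated time of 48 h (a higher number here means a weaker inhibitor, a lower number a stronger inhibitor), the lowest of the three numbers measured so far. Its nearest neighbour is compound 1 `Fc1ccc2[nH]c(-c3cn(-c4ccccc4)nc3-c3ccccc3)nc2c1`, which gives 1720 nM, and the furthest is compound 2 `Brc1ccc2[nH]c(-c3cn(-c4ccccc4)nc3-c3ccccc3)nc2c1`, which gives 1810 nM; both gaps lie within the scatter, so no ranking among the three can be drawn from them. Compound 4 `Fc1ccc(-c2nn(-c3ccccc3)cc2-c2nc3cc(Br)ccc3[nH]2)cc1` is the unmeasured partner of compound 3 and differs from it in one place: bromo in place of fluoro on an aromatic carbon.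

Within the data shown here, one measured step bears directly on this change. The same exchange, bromo in place of fluoro on an aromatic carbon, occurs once among the measured compounds, where it gave a 1.1-fold higher number from compound 1 to compound 2 (0.02 log units; within the scatter). The other step, a 1.5-fold lower number from compound 1 to compound 3 (0.18 log units; within the scatter), concerns fluoro in place of hydrogen and does not touch the position altered here. Among the measured compounds shown here, with the only comparable step having produced no movement beyond the scatter, the step into compound 4 is expected to be small and of no settled direction.

On that basis compound 4 is estimated to give 1200 nM in this assay, between 600 nM and 2400 nM. This estimate corresponds to an expected step of a 1.1-fold higher number from compound 3 to compound 4 (0.03 log units; within the scatter).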

Compound 4, half-maximal inhibitory concentration: 5830 nM
Compound 4: the middle estimate sits 4.9-fold (0.69 log units) below what was measured; measured number outside the range, above it.
By their numbers in this assay, from the lowest: compounds 3, 1 and 2 (each within the scatter of the next); then compound 4.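

Bromo in place of fluoro on the fused ring gave a 5.2-fold higher number from compound 3 to compound 4 (0.71 log units; beyond the scatter) in this assay, so this position is not indifferent to the exchange when the core also carries the fluoro that sets compound 3 apart from compound 1. The exchange therefore does not carry over unchanged from one core to the other: the same change on two cores in this assay, a 1.1-fold higher number (0.02 log units; within the scatter) from compound 1 to compound 2 and a 5.2-fold higher number (0.71 log units; beyond the scatter) from compound 3 to compound 4, 4.9-fold (0.69 log units) apart, beyond the scatter of two such steps The same dependence appears from the other side, since fluoro in place of hydrogen gave a 3.2-fold higher number from compound 2 to compound 4 (0.51 log units; beyond the scatter) with bromo on the fused ring, whereas with fluoro there its step stayed within the scatter: the same change on two cores in this assay, a 1.5-fold lower number (0.18 log units; within the scatter) from compound 1 to compound 3 and a 3.2-fold higher number (0.51 log units; beyond the scatter) from compound 2 to compound 4, 4.9-fold (0.69 log units) apart, beyond the scatter of two such steps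

The compounds shown do not tell why the two changes depend on each other, and with only four compounds on two cores, the dependence cannot be claimed beyond them. As far as these compounds go, it also remains open where chloro or an amine at this position would fall on either core, and whether such groups would show the same dependence on the second fluoro.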